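The source may report more compounds than this note shows. Statements on the series, on what has been measured and on what is new or still open speak of the compounds shown alone.

Measured in an assay on U2OS cells for inhibition of secreted frizzled-related protein 1 (Homo sapiens), read by a luciferase reporter, with a stated time of 18 h (on this read-out lower numbers stand for an effect already at smaller amounts and higher numbers for an effect only at larger amounts of compound), so far:
compound 1 `O=C(c1ccccc1)N1CCC(NS(=O)(=O)c2cc(S(=O)(=O)c3ccccc3)ccc2C(F)(F)F)CC1` gives 250 nM;
compound 2 `O=C(c1ccccn1)N1CCC(NS(=O)(=O)c2cc(S(=O)(=O)c3ccccc3)ccc2C(F)(F)F)CC1` gives 230 nM.

The number for compound 2 is the lower of the two, yet a 1.1-fold lower number from compound 1 to compound 2 (0.04 log units; within the scatter) lies within the scatter, so neither compound stands apart. Compound 3 `O=S(=O)(NC1CCN(S(=O)(=O)c2ccccc2)CC1)c1cc(S(=O)(=O)c2ccccc2)ccc1C(F)(F)F` differs from compound 2 in one place: phenylsulfonyl in place of (pyridin-2-yl)carbonyl on an amine nitrogen in a ring. Among the compounds with values here, the only measured step exchanged one aryl group for another on a carbonyl carbon and stayed within the scatter; no measured step tests a sulfonyl in place of a carbonyl on the ring nitrogen, so the size of this change is not grounded in the data. Compound 3 is therefore expected near compound 2, at an estimated 300 nM with a range from 100 nM to 900 nM. The expected step is a 1.3-fold higher number from compound 2 to compound 3 (0.12 log units; within the scatter).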

Compound 3, half-maximal effective concentration: 210 nM
Compound 3: middle estimate off by 1.4-fold (0.15 log units), on the high side; the range from low to high includes it.
By their numbers in this assay, from the lowest: compounds 3, 2 and 1 (each within the scatter of the next).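

On the amine nitrogen in the ring, a sulfonyl link to the aromatic ring can replace a carbonyl link without separating the compounds in this assay: the result is a 1.1-fold lower number from compound 2 to compound 3 (0.04 log units; within the scatter) and a 1.2-fold lower number from compound 1 to compound 3 (0.08 log units; within the scatter). The earlier pair had varied only the aryl group on a carbonyl carbon, whereas these steps change the link itself. No further data bear on this result.

All three compounds carry an aromatic ring on this nitrogen. From the compounds shown here alone, what an acetyl group or a free amine there would do to the number stays open.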